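Trading a methoxypyridinyl ether for a trifluoromethylphenyl ether

A few compounds are considered here, and "the series" means these few. Any claim that something is new, unique, unknown or untested is made for them only; others in the source may bear on it.

Of the compounds shown here, three sharing one core have been tested in an ADME assay on PBMC cells (Homo sapiens) for cytotoxicity; a higher number here means that more compound is tolerated, a lower number that less compound is tolerated. Compound 1 `COc1cccc(OC(c2ccc(C(F)(F)F)cc2)C2CCN(C(C)CCNC(=O)c3c(Cl)cncc3Cl)CC2)n1` gives 32700 nM there. Compound 2 `CCO/N=C(/c1ccc(Br)cc1)C1CCN(C(C)(C)CCNC(=O)c2c(Cl)cncc2Cl)CC1` gives 34000 nM in this assay, and this number and that of compound 1 lie within the usual scatter of each other, so neither can be called better tolerated. Compound 3 `CCO/N=C(/c1ccc(Br)cc1)C1CCN(C(CC)CCNC(=O)c2c(C)cc[n+]([O-])c2C)CC1` reaches only a limit of this assay, > 177000 nM, rather than a number. That is the limit of > 177000 nM in this assay, at which 1 of the 3 values shown sits.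

Compound 4 `CC(CCNC(=O)c1c(Cl)cncc1Cl)N1CCC(C(Oc2ccc(C(F)(F)F)cc2)c2ccc(C(F)(F)F)cc2)CC1` is not yet measured. It differs from compound 1 in one place: 4-(trifluoromethyl)phenyl in place of 6-methoxypyridin-2-yl on an oxygen on a saturated carbon. For the measured compounds named here, no pair of measured compounds shows a comparable change, so there is no measured step to lean on. The expectation is therefore a step in this assay of no more than the scatter, in either direction. Compound 4 is expected to give about 28000 nM, with a likely range from 9000 nM to 90000 nM. This estimate means an expected step of a 1.2-fold lower number from compound 1 to compound 4 (0.07 log units; within the scatter) that stays within the usual scatter.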

Compound 4, half-maximal cytotoxic concentration: 3100 nM
Beside the measured number, compound 4's estimate is 9.0-fold (0.96 log units) above it; the whole stated range lies above it.
By their numbers in this assay, from the lowest: compound 4; then compounds 1 and 2 (each within the scatter of the next). At a limit, above all of these: compound 3.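

Putting 4-(trifluoromethyl)phenyl in place of 6-methoxypyridin-2-yl on this oxygen gives an 11-fold lower number from compound 1 to compound 4 (1.02 log units; beyond the scatter) in this assay, so the cells tolerate much less of the new compound. This is the first step among the compounds shown, and it establishes that changing this one group is enough to move the tolerated concentration well beyond the scatter. The change replaces a ring containing nitrogen and carrying a methoxy group with a carbon-only ring carrying trifluoromethyl, and nothing measured here tells which of these differences matters, or why.

Still open, on these data alone, is whether an unsubstituted phenyl or a pyridine without the methoxy group on this oxygen would fall nearer compound 1 or compound 4. Also open, as far as these compounds go, is how an amine or a carboxylic acid on this ring would behave in this assay.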